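Removing the ethenyl linker from a weakly active purine amide

The compounds below may be only part of what the source reports. "The series", "measured", "known", "first", "only" and "open" are said of these compounds alone.

Of the compounds shown here, two have been measured so far. Compound 1 `CCCCn1cnc2c(Nc3cccc(Cl)c3)nc(NCOCc3ccc(/C=C/C(=O)Nc4ccccc4N)cc3)nc21` is tested in a functional assay on HCT-116 cells (Homo sapiens) for antiproliferative activity, read by CCK-8 assay, with a stated time of 72 h, tested at 2 uM (on this read-out lower numbers stand for a weaker effect and higher numbers for a stronger effect at the one concentration tested), where compound 1 gives 4.76%. Compound 2 `CCCCn1cnc2c(Nc3ccccc3)nc(NCOCc3ccc(/C=C/C(=O)Nc4ccccc4N)cc3)nc21` differs from compound 1 only in having hydrogen in place of chloro on an aromatic carbon, and in this assay compound 2 gives 6.58%. For the measured compounds named here, the one measured step, a number 1.8 percentage points higher from compound 1 to compound 2 (within the scatter), therefore tells of two numbers that cannot be told apart. Compound 1 gives the lowest of the two numbers, but its nearest neighbour, compound 2, lies within the scatter, so no order can be read from this.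

Compound 3 `CCCCn1cnc2c(Nc3cccc(Cl)c3)nc(NCOCc3ccc(C(=O)Nc4ccccc4N)cc3)nc21` has not been measured in this assay. It differs from compound 1 by (2-aminophenyl)carbamoyl in place of 2-((2-aminophenyl)carbamoyl)ethenyl on an aromatic carbon, so the chain between the aromatic ring and the carbonyl is shortened. Going by the values given here, no measured step touches this place; the step from compound 1 to compound 2 concerns the chloro group only. With nothing to point either way, the expectation for compound 3 is a number near that of compound 1, an estimated step of a number 0.2 percentage points higher from compound 1 to compound 3 (within the scatter). The estimate for compound 3 in this assay is 5%, with a range from -5% to 25%.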

Compound 3, a percentage reported as inhibition, at one concentration (the size of the read-out at that concentration, not a potency): 58.9%
The estimate for compound 3 lay 53.9 percentage points below the measured number; the whole stated range lies below it.
By their numbers in this assay, from the lowest: compounds 1 and 2 (each within the scatter of the next); then compound 3.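

In this assay, the place on the aromatic ring para to a large group proves far more sensitive than the chloro position: exchanging 2-((2-aminophenyl)carbamoyl)ethenyl for (2-aminophenyl)carbamoyl gives a number 54.1 percentage points higher from compound 1 to compound 3 (beyond the scatter) while removing the chloro group gave only a number 1.8 percentage points higher from compound 1 to compound 2 (within the scatter) in the earlier comparison. The exchange itself is small on paper, with fewer heavy atoms entering than leaving, one double bond outside aromatic rings fewer, and the same counts of hydrogen-bond donors and acceptors, so a modest trim of the chain separates a near-inactive compound from a clearly active one at this single concentration. Nothing measured alongside these numbers accounts for the large rise.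

The compounds shown leave open whether the loss of the double bond or the shorter chain matters more, a question that a saturated two-carbon chain between the ring and the carbonyl could help to separate. They also leave open whether the amide must stay, as a hydroxamic acid in place of the (2-aminophenyl)carbamoyl group would test, and whether the chloro group makes any difference once the ethenyl part is gone.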